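Third methoxy on the benzylamine aryl of compound 2

The source may hold more compounds than are shown below. What is called first, only, known or untested is meant among the compounds shown, and "the series" means these compounds.

Among the measured compounds shown here, compound 2 `COc1ccc(CNc2nc3cc(N)cc(N)c3nc2-c2ccccc2)cc1OC` is the weaker of the two measured members: in a functional assay on U-251 cells (Homo sapiens) for inhibition, read by sulforhodamine B assay, with a stated time of 48 h (on this read-out higher numbers stand for weaker inhibition of growth and lower numbers for stronger inhibition of growth), compound 2 gives 17000 nM, whereas compound 1 `Nc1cc(N)c2nc(-c3ccccc3)c(NCc3ccc(Cl)c(Cl)c3)nc2c1` gives 2090 nM in this assay. For the measured compounds named here, the only measured step, an 8.1-fold higher number from compound 1 to compound 2 (0.91 log units; beyond the scatter), concerns a full exchange of the aryl group on the same chain carbon and moved the number upward. Compound 3 `COc1cc(CNc2nc3cc(N)cc(N)c3nc2-c2ccccc2)cc(OC)c1OC` is not yet measured; it differs from compound 2 by methoxy in place of hydrogen on an aromatic carbon. Going by the values given here, no measured pair isolates the addition of one methoxy to an aryl that already carries two, so the 1>2 step speaks to it only indirectly: further methoxy substitution sits on the side of that step that weakened growth inhibition. The expected step of a 1.3-fold higher number from compound 2 to compound 3 (0.11 log units; within the scatter) is therefore small, leaning toward a higher number, and may not exceed the scatter. For compound 3 the estimate in this assay is 22000 nM, within 8000 nM to 60000 nM.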

Compound 3, concentration for 50% growth inhibition: 1740 nM
Estimate against measurement, compound 3: 13-fold (1.10 log units) above, and the stated range ends above it.
By their numbers in this assay, from the lowest: compounds 3 and 1 (each within the scatter of the next); then compound 2.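

In this assay, methoxy in place of hydrogen on this aromatic carbon, ortho to a methoxy group and meta to a large group, gives a 9.8-fold lower number from compound 2 to compound 3 (0.99 log units; beyond the scatter). A single change at this carbon therefore moves the number well beyond the scatter, and across compounds 2 and 3 more methoxy on the aryl goes with stronger, not weaker, inhibition of growth, while compounds 3 and 1 stand within the scatter of each other even though their aryl groups differ. No measurement on hand bears on the reason for this step. Open, going by these compounds, is whether the gain needs methoxy itself or would also appear with a hydroxy or an ethoxy on the same carbon. Also open, on these data alone, is whether a chloro added at this carbon to the 3,4-dichlorophenyl of compound 1 would shift the number at all.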